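The source may hold more compounds than are shown below. What is called first, only, known or untested is meant among the compounds shown, and "the series" means these compounds.

Among the measured compounds shown here, in a functional assay on A549 cells (Homo sapiens) for inhibition, read by MTT assay, with a stated time of 48 h (a lower number here means a stronger inhibitor, a higher number a weaker inhibitor), compound 1 (`COc1ccc2c(=O)c(/C=C/C(=O)Nc3cc(C)ccc3C)coc2c1`) gives 15500 nM and compound 2 (`COc1ccc2c(=O)c(/C=C/C(=O)NCc3cccc(F)c3)coc2c1`) gives 26900 nM as the only two numbers at hand, and these lie within the scatter of each other. Compound 3 (`COc1ccc2c(=O)c(/C=C/C(=O)NCc3ccccc3F)coc2c1`) differs from compound 2 in one place (2-fluorophenyl in place of 3-fluorophenyl on a saturated chain carbon bound to an amide-type nitrogen): 2-fluorophenyl in place of 3-fluorophenyl on a saturated chain carbon bound to an amide-type nitrogen. For the measured compounds named here, the only measured step bearing on this (a 1.7-fold higher number from compound 1 to compound 2 (0.24 log units; within the scatter)) exchanges the whole group on the amide-type nitrogen and stays within the scatter. Going by the values given here, no measured pair tests the place of the fluorine alone. A step beyond the scatter is therefore not expected in this assay for this change. For compound 3 the estimated value is 24000 nM with an expected range from 11000 nM to 50000 nM in this measurement. The expected shift (a 1.1-fold lower number from compound 2 to compound 3 (0.05 log units; within the scatter)) remains within the scatter.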

Compound 3, half-maximal inhibitory concentration: > 100000 nM
Compound 3 was reported as a limit; the forecaster's own chance of this, stated with the estimate: 8%; middle value at least 4.1-fold (0.61 log units) away from the limit.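

The place of the fluorine alone, with the same atoms joined differently, gives a step beyond the scatter in this assay: 3-fluorobenzyl to 2-fluorobenzyl yields an at least 3.7-fold higher number from compound 2 to compound 3 (0.57 log units; beyond the scatter), whereas the earlier exchange of the whole group on the amide-type nitrogen stayed within the scatter. Against 2,5-dimethylphenyl on the amide-type nitrogen, 2-fluorobenzyl also lies beyond the scatter, with an at least 6.4-fold higher number from compound 1 to compound 3 (0.80 log units; beyond the scatter), so this position tolerates the 3-fluorobenzyl group but not the 2-fluorobenzyl group in this series. The reading for compound 3 is a limit of the assay and not a number: the limit of > 100000 nM in this assay, at which 1 of the 3 values shown sits.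

From the compounds shown here alone, how far the loss extends stays open, and so does whether it belongs to fluorine itself or to any group at that place. Unsubstituted benzyl, 4-fluorobenzyl, 2-chlorobenzyl and 2-methylbenzyl on the same nitrogen would each bear on that question.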